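Amine replacements on the propargylsulfanyl core: compound 4

This account rests on a few compounds, and the source may have more. Where it says the series, first, only, none or still open, it means among the compounds named here.

Measured so far:
compound 1 `C#CCSc1nc(NCCC(C)C)c2ccncc2n1` gives > 80000 nM in a functional assay on HepG2 cells (Homo sapiens) for inhibition, read by MTT assay, with a stated time of 72 h (a lower number here means a stronger inhibitor, a higher number a weaker inhibitor), a limit of the assay
compound 2 `C#CCSc1nc(Nc2ccccc2O)c2ccncc2n1` gives > 80000 nM, again a limit
compound 3 `C#CCSc1nc(Nc2cccc(O)c2)c2ccncc2n1` gives 29500 nM

Compound 1 stands only at a limit, so its place among the three cannot be fixed; the limit of > 80000 nM in this assay, at which 2 of the 3 values shown sit, is where compound 1 and compound 2 both sit, and compound 3 alone returns a number. The steps read a step that the two limits leave unreadable from compound 1 to compound 2, an at least 2.7-fold lower number from compound 1 to compound 3 (0.43 log units; beyond the scatter) and an at least 2.7-fold lower number from compound 2 to compound 3 (0.43 log units; beyond the scatter).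

Compound 4 `C#CCSc1nc(N2CCN(C)CC2)c2ccncc2n1` differs from compound 1 by 4-methylpiperazin-1-yl in place of isopentylamino on an aromatic carbon. Among the measured compounds shown here, no measured step exchanges the isopentylamino group for a saturated ring that carries no hydrogen-bond donor; the two steps that start from compound 1 swap the isopentyl for a hydroxyphenyl and keep the hydrogen on the nitrogen, so they bear on this change only through the shared departing group, and one of them is unreadable while the other is at least modest downward. Since compound 1 sits at a limit, no direction of change from it can be read, and the expectation is that compound 4 most likely also reports a limit or a number near it.

The estimate for compound 4 in this assay is 80000 nM, from 25000 nM to 250000 nM.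

That estimate means an expected step of a number no higher from compound 1 to compound 4 (the limit leaves the size open).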

Compound 4, half-maximal inhibitory concentration: > 80000 nM
Compound 4 was reported as a limit; the forecaster's own chance of this, stated with the estimate: 60%; the middle value lies on the limit itself.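

In this assay compound 4 gives > 80000 nM, a limit of the assay. Compound 1 also stands at a limit, so no new step can be read between compound 1 and compound 4: the limit of > 80000 nM in this assay, at which 3 of the 4 values shown sit.

The compounds shown leave open whether 4-methylpiperazin-1-yl in place of isopentylamino changes the inhibition at all, and in which direction.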